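Phenyl for pyrrolyl on the cyano-bearing bicyclic core

This account rests on a few compounds, and the source may have more. Where it says the series, first, only, none or still open, it means among the compounds named here.

The series is measured in an assay on isolated protein for binding affinity to Leucine-rich repeat serine/threonine-protein kinase 2 variant G2019S (Homo sapiens), read by TR-FRET and LanthaScreen, with a stated time of 2 h; a lower number here means a stronger inhibitor, a higher number a weaker inhibitor. Compound 1 `CN(C)c1c(C#N)c2c(N)ncnc2n1C` gives 259 nM. Compound 2 `Cn1c(-n2cccc2)c(C#N)c2c(N)ncnc21` gives 1980 nM, the highest number among the three, while compound 3 `C[C@@H]1CCCN1c1c(C#N)c2c(N)nccc2n1C`, which differs in both its ring substituent and its core, gives 2 nM. Going by the values given here, compound 2 is thus the weakest of the three, and the only single-point step that reaches it is a 7.6-fold higher number from compound 1 to compound 2 (0.88 log units; beyond the scatter).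

The unmeasured compound 4 `Cn1c(-c2ccccc2)c(C#N)c2c(N)ncnc21` differs from compound 2 in one place: phenyl in place of 1H-pyrrol-1-yl on an aromatic carbon. Among the compounds with values here, no measured pair replaces a 1H-pyrrol-1-yl by a phenyl, so the one relevant step, a 7.6-fold higher number from compound 1 to compound 2 (0.88 log units; beyond the scatter), only shows how far a change of the group at this aromatic carbon has moved the number here. Since both groups are single aromatic rings, the step from compound 2 to compound 4 is expected to be modest, with a slight lean toward a lower number, as a 1.3-fold lower number from compound 2 to compound 4 (0.12 log units; within the scatter). For compound 4 the expected value in this assay is therefore 1500 nM, within a range from 400 nM to 6000 nM.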

Compound 4, inhibition constant: 33 nM
Compound 4: the middle estimate sits 45-fold (1.66 log units) above what was measured; the whole stated range lies above it.
By their numbers in this assay, from the lowest: compound 3; then compound 4; then compound 1; then compound 2.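

Two single aromatic rings at this aromatic carbon are not interchangeable in this assay: phenyl in place of 1H-pyrrol-1-yl gives a 60-fold lower number from compound 2 to compound 4 (1.78 log units; beyond the scatter), a large step. Phenyl in place of dimethylamino gives a 7.8-fold lower number from compound 1 to compound 4 (0.89 log units; beyond the scatter), so among these three groups on the shared core dimethylamino falls between the two aromatic rings, and being an aromatic ring does not by itself set the order. Nothing available explains why phenyl and 1H-pyrrol-1-yl differ so widely here.

The compounds shown leave open whether a pyridine ring, a phenyl ring carrying a fluorine, or a morpholine would hold or lose what phenyl gains at this carbon. They also leave open how phenyl would behave on the core of compound 3, which differs from compound 4 in more than one place.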